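One Nitro Group Fewer on Compound 2

The source may hold more compounds than are shown below. What is called first, only, known or untested is meant among the compounds shown, and "the series" means these compounds.

Of the compounds shown here, two sharing one core have been tested in an ADME assay on BEAS-2B cells (Homo sapiens) for cytotoxicity, read by MTT assay, with a stated time of 72 h; on this read-out lower numbers stand for stronger inhibition of growth and higher numbers for weaker inhibition of growth. Compound 1 `CCCCCCOC(=O)Nc1ccc([Se]C#N)cc1` gives 2800 nM. Compound 2 `N#C[Se]c1ccc(NC(=O)OCc2ccc([N+](=O)[O-])cc2)cc1` gives 7700 nM, the higher of the two numbers, so compound 2 inhibits growth less strongly than compound 1, a gap beyond the usual scatter. Compound 3 `N#C[Se]c1ccc(NC(=O)OCc2ccccc2)cc1` has not yet been measured; it differs from compound 2 by hydrogen in place of nitro on an aromatic carbon. Within the data shown here, no measured pair shows this kind of change, so only a modest step in this assay is expected, in either direction. The expected change is a 1.4-fold lower number from compound 2 to compound 3 (0.15 log units; within the scatter), hardly beyond the scatter. Compound 3 is thus expected to give about 5500 nM, within 2000 nM to 15000 nM.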

Compound 3, concentration for 50% growth inhibition: 100 nM
Compound 3: middle estimate off by 55-fold (1.74 log units), on the high side, outside the stated range (below it).
By their numbers in this assay, from the lowest: compound 3; then compound 1; then compound 2.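

In this assay, hydrogen in place of nitro on an aromatic carbon is far from a minor edit: a 77-fold lower number from compound 2 to compound 3 (1.89 log units; beyond the scatter) shows that this position can strongly change the read-out. Phenyl in place of pentyl on the saturated chain carbon gives a 28-fold lower number from compound 1 to compound 3 (1.45 log units; beyond the scatter) and leaves compound 3 with the lowest number of the three. No available data explain either step.

The compounds shown leave open how an amine or a methoxy group would behave at the same ring position. From the compounds shown here alone, a longer chain in place of the benzyl group also remains untested here.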